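Hydrogen in place of methoxy on compound 1

The source may report more compounds than this note shows. Statements on the series, on what has been measured and on what is new or still open speak of the compounds shown alone.

Measured so far in a functional assay on HeLa cells (Homo sapiens) for antiproliferative activity, read by resazurin assay (a higher number here means a weaker inhibitor, a lower number a stronger inhibitor), with these values:
- compound 1 `CCSC(=S)SCC(=O)c1ccc(OC)cc1OC` gives 12600 nM
- compound 2 `CSC(=S)SCC(=O)c1ccc(Cl)c(Cl)c1` gives 6310 nM
- compound 3 `CCOC(=O)Nc1cccc(C(=O)CSC(=S)SCC)c1` gives 2000 nM

Compound 1 gives the highest of the three numbers, level within the scatter with compound 2, while compound 3 stands lower by more than the scatter. Compound 4 `CCSC(=S)SCC(=O)c1ccc(OC)cc1` differs from compound 1 by one change (hydrogen in place of methoxy on an aromatic carbon), hydrogen in place of methoxy on an aromatic carbon, and a methoxy group remains on the ring.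

Among the compounds with values here, no two measured compounds differ in one place only, so the series gives no direct measure of this change. The lowest measured number is that of compound 3 with 2000 nM and the highest that of compound 1 with 12600 nM, and these leave little basis for a large move. In this assay no step beyond the scatter is expected, with a slight lean toward a lower number. The estimated step is a 1.4-fold lower number from compound 1 to compound 4 (0.15 log units; within the scatter) and it stays within the scatter. Compound 4 is expected at 9000 nM with an estimated range of 3500 nM to 22000 nM in this series.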

Compound 4, half-maximal inhibitory concentration: 2510 nM
The estimate for compound 4 lay 3.6-fold (0.55 log units) above the measured number; measured number below the stated range.
By their numbers in this assay, from the lowest: compounds 3 and 4 (each within the scatter of the next); then compounds 2 and 1 (each within the scatter of the next).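

In this assay, within the data shown here, exchanging the methoxy group ortho to a group of 9 heavy atoms for hydrogen gives a 5.0-fold lower number from compound 1 to compound 4 (0.70 log units; beyond the scatter), the first one-place step and one that lies beyond the scatter. This position therefore responds to its substituent, with hydrogen giving the lower number than methoxy while the methoxy group meta to this carbon stays in place. Nothing shown accounts for the size of this step.

Still open, as far as these compounds go, is how other groups at this aromatic carbon would compare with hydrogen and methoxy, for example fluorine, an amine or a longer ethoxy chain. Also open, from the compounds shown here alone, is whether the remaining methoxy group contributes to the number of compound 4, which would take hydrogen or a hydroxyl group in its place to show.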